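A thiophene core: ketone to ester, effect expected small

A few compounds are considered here, and "the series" means these few. Any claim that something is new, unique, unknown or untested is made for them only; others in the source may bear on it.

In an assay on membranes from HeLa cells for displacement of a labelled ligand from adenosine receptor A3 (Homo sapiens), read by scintillation counting, with a stated time of 180 min, tested at 1 uM (on this read-out higher numbers stand for more inhibition at the one concentration tested (going by the name of the read-out) and lower numbers for less inhibition), compound 2 `CC1=C(C(=O)CC(C)C)C(c2cccs2)NC(=O)N1` gives 18%, level with compound 1 `CC1=C(C(=O)CC(C)C)C(c2ccoc2)NC(=O)N1` at 18%, and no change at the digits printed from compound 1 to compound 2 (within the scatter). Compound 3 `CC1=C(c2ncc(C)o2)C(c2cccs2)NC(=O)N1` gives 1%, so that a number 17 percentage points lower from compound 2 to compound 3 (beyond the scatter). Compound 4 `CC1=C(C(=O)OCC2CCC2)C(c2cccs2)NC(=O)N1` differs from compound 2 by cyclobutylmethoxy in place of isobutyl on a carbonyl carbon. The step from compound 1 to compound 2 concerns a different position and bears little; the step from compound 2 to compound 3 replaces the whole group at the same ring carbon and is modest, whereas here the carbonyl stays and only its substituent changes. A small decrease, or none beyond the scatter, is therefore expected, namely a number 6 percentage points lower from compound 2 to compound 4 (within the scatter). Compound 4 is estimated at 12%, with a range from 0% to 28%.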

Compound 4, a percentage reported as inhibition, at one concentration (the size of the read-out at that concentration, not a potency): 1%
Compound 4: middle estimate off by 11 percentage points, on the high side; low and high end bracket the measured number.
By their numbers in this assay, from the lowest: compounds 3 and 4 (each within the scatter of the next); then compounds 1 and 2 (each within the scatter of the next).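

In this assay, keeping the carbonyl at this position did not preserve the read-out: cyclobutylmethoxy in place of isobutyl on a carbonyl carbon gives a number 17 percentage points lower from compound 2 to compound 4 (beyond the scatter). That step equals in size the one for replacing the whole group at the double-bonded ring carbon, a number 17 percentage points lower from compound 2 to compound 3 (beyond the scatter), so changing the carbonyl substituent alone is enough to produce a drop of this size. Nothing measured here explains the drop.

The compounds shown do not separate the entering oxygen from the four-membered ring. Ethoxy or cyclobutylmethyl on the same carbonyl carbon would tell the two apart.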